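The source may hold more compounds than are shown below. What is called first, only, known or untested is meant among the compounds shown, and "the series" means these compounds.

Three thiosemicarbazones built on a shared core of two fused rings were examined in a toxicity assay on MRC5 cells (Homo sapiens) for cytotoxicity, read by MTT assay, with a stated time of 72 h; on this read-out lower numbers stand for an effect already at smaller amounts and higher numbers for an effect only at larger amounts of compound. Compound 1 `Cn1c(/C=N/N=C(/N)S)cc2ccccc21` was among them. In this assay compound 1 gives > 200000 nM, which is a limit of the assay and not a number. Compound 3 `CN(C)c1ccc(/C=N/N=C(/N)S)c2ccccc12` was examined in the same way. In this assay compound 3 gives > 200000 nM, again a limit rather than a number. Compound 2 `Cc1ccc(/C=N/NC(N)=S)c2ccccc12` is the only one of the three that yields an actual number: in this assay compound 2 gives 37000 nM. Among the compounds with values here, the other two values both sit at the limit of > 200000 nM in this assay, at which 2 of the 3 values shown sit, so compound 2 stands alone as the sole measured number and cannot be ordered against the others beyond that.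

Compound 4 `NC(=S)N/N=C/c1ccc(OCC2CCCCC2)c2ccccc12` has not yet been measured. It differs from compound 2 by cyclohexylmethoxy in place of methyl on an aromatic carbon. Within the data shown here, no two measured compounds differ in one place, so no measured step guides the expectation directly. A step of a 2.1-fold lower number from compound 2 to compound 4 (0.31 log units; beyond the scatter) is expected, toward an effect at smaller amounts, of a size only a little beyond the scatter. Compound 4 is accordingly estimated at 18000 nM, with a range from 5000 nM to 70000 nM.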

Compound 4, half-maximal effective concentration: 28900 nM
Estimate against measurement, compound 4: 1.6-fold (0.21 log units) below; the measured number falls inside the stated range.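

In this assay, cyclohexylmethoxy in place of methyl, on an aromatic carbon para to a group of 6 heavy atoms, gives a 1.3-fold lower number from compound 2 to compound 4 (0.11 log units; within the scatter), the only step shown between compounds that differ in one place. This position therefore carries a group of 8 heavy atoms, with a six-membered non-aromatic ring of carbon only and a hydrogen-bond acceptor, in place of a single methyl carbon, and the read-out stays within the scatter. Compounds 1 and 3 cannot be set against this pair, as their values are limits of the assay and not numbers: the limit of > 200000 nM in this assay, at which 2 of the 4 values shown sit.

This single pair leaves open whether the read-out would stay the same with a carboxylic acid, a hydroxyl or a longer straight alkyl chain on this aromatic carbon. It also leaves open whether cyclohexylmethoxy would behave alike at another aromatic carbon of the shared core, and what the step would be if a number could be read in place of a limit.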